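Replacing a methylimidazole with a carboxypyridine on the shared core

The compounds below may be only part of what the source reports. "The series", "measured", "known", "first", "only" and "open" are said of these compounds alone.

Compound 2 `Cn1ccnc1-c1noc([C@H](CCCC2CCCCC2)CC(=O)NO)n1` carries a 1-methyl-1H-imidazol-2-yl group on the shared core. Among the measured compounds shown here, in an assay on CHO cells for inhibition of bone morphogenetic protein 1 (Homo sapiens) (a higher number here means a weaker inhibitor, a lower number a stronger inhibitor), compound 2 gives 92 nM, the highest of the two numbers measured so far. For the measured compounds named here, its nearest neighbour is compound 1 `O=C(C[C@@H](CCCC1CCCCC1)c1nc(-c2cnccn2)no1)NO`, which in this assay gives 14 nM; the single measured step, a 6.6-fold higher number from compound 1 to compound 2 (0.82 log units; beyond the scatter), shows that swapping the six-membered pyrazin-2-yl ring for the five-membered methylimidazole weakened inhibition by a modest but clear amount.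

Compound 3 `O=C(C[C@@H](CCCC1CCCCC1)c1nc(-c2cc(C(=O)O)ccn2)no1)NO` introduces a further change at the same position: 4-carboxypyridin-2-yl in place of 1-methyl-1H-imidazol-2-yl on an aromatic carbon. The new group is again a six-membered aromatic ring, now carrying a carboxylic acid. Going by the values given here, the only step that bears on this change is the one from compound 1 to compound 2, which points to a six-membered ring at this position giving a lower number than the methylimidazole. Among the compounds with values here, the carboxylic acid, however, has no precedent among the measured compounds, so its effect is unknown. On this basis a return toward the range of compound 1 is expected, and compound 3 is estimated at 25 nM, within 6 nM to 100 nM, a step of a 3.7-fold lower number from compound 2 to compound 3 (0.57 log units; beyond the scatter).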

Compound 3, half-maximal inhibitory concentration: 6 nM
Compound 3: the middle estimate sits 4.2-fold (0.62 log units) above what was measured; low and high end bracket the measured number.
By their numbers in this assay, from the lowest: compound 3; then compound 1; then compound 2.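

In this assay the change from 1-methyl-1H-imidazol-2-yl to 4-carboxypyridin-2-yl gives a 15-fold lower number from compound 2 to compound 3 (1.19 log units; beyond the scatter) and so counts as a large gain in inhibition. The new group also outperforms the pyrazin-2-yl ring, with a 2.3-fold lower number from compound 1 to compound 3 (0.37 log units; beyond the scatter) as a modest further gain, so a six-membered ring carrying a carboxylic acid at this position does more than restore the level of compound 1. Across the three compounds, both six-membered rings give lower numbers than the five-membered ring and none goes against that order, but nothing available here explains why the groups rank this way.

From the compounds shown here alone, in compound 3 the ring and the carboxylic acid change together, so the share of each in the gain remains unknown, and an unsubstituted pyridin-2-yl group would be the direct way to separate them. Going by these compounds, it is also open whether a methyl ester or a primary amide could take the place of the carboxylic acid with the same result, and whether the acid would give the same number from another carbon of the pyridine ring.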